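Dopamine receptor agonists: removing the aromatic fluoro in compound 1

A few compounds are considered here, and "the series" means these few. Any claim that something is new, unique, unknown or untested is made for them only; others in the source may bear on it.

Measured compounds:
- compound 1, `Cc1cc(C(=O)NCN2CCC(c3cccc[n+]3[O-])CC2)ccc1F`: 50 nM
- compound 2, `Cc1cccc(NC(=O)CN2CCC(c3nccs3)CC2)c1`: 1 nM

In a functional assay on HEK293 cells for agonist activity at D(4) dopamine receptor (Homo sapiens), read by FLIPR (on this read-out higher numbers stand for an effect only at larger amounts of compound and lower numbers for an effect already at smaller amounts), compound 1 gives 50 nM, the highest of the two numbers recorded. The only other measured entry, compound 2, gives 1 nM in this assay, a lower number that lies well beyond the usual scatter. Among the compounds with values here, compound 2 differs from compound 1 in several places at once, so no single-point step between the two is available and nothing can be read from that pair about any one group.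

Compound 3, `Cc1cccc(C(=O)NCN2CCC(c3cccc[n+]3[O-])CC2)c1`, not yet measured, differs from compound 1 in one place only: hydrogen in place of fluoro on an aromatic carbon. Within the data shown here, no measured pair shows this change on its own, so the expectation rests on the size of the change alone. It is expected that the step of a 1.3-fold lower number from compound 1 to compound 3 (0.10 log units; within the scatter) stays within the scatter, with no clear direction. Compound 3 is therefore estimated at 40 nM in this assay, with a range from 12 nM to 150 nM.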

Compound 3, half-maximal effective concentration: 89 nM
Beside the measured number, compound 3's estimate is 2.2-fold (0.35 log units) below it, within the range that was stated.
By their numbers in this assay, from the lowest: compound 2; then compounds 1 and 3 (each within the scatter of the next).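

In this assay, within the data shown here, the change from 4-fluoro-3-methylphenyl to 3-methylphenyl gives the first single-place step, a 1.8-fold higher number from compound 1 to compound 3 (0.25 log units; within the scatter), so the read-out does not separate the two compounds. At this aromatic carbon, ortho to a methyl group and para to a large group, the fluoro is therefore not required for activity in the range of compound 1, though a small contribution inside the scatter cannot be excluded. No measurement available here bears on the reason for this outcome.

As far as these compounds go, whether larger replacements on this carbon, such as chloro, methoxy or an amine, would also stay within the scatter of compound 1 remains open. Also open, from the compounds shown here alone, is what the methyl group contributes, since it stays in place across this step.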